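Moving the methyl group on the styryl arm of compound 1

The source may report more compounds than this note shows. Statements on the series, on what has been measured and on what is new or still open speak of the compounds shown alone.

Measured so far:
- compound 1 `Cc1ccc(/C=C/c2nnc(-c3ccc4c(c3)OCCO4)o2)cc1`: 45200 nM
- compound 2 `Fc1ccc(/C=C/c2nnc(-c3ccc4c(c3)OCCO4)o2)cc1`: 4960 nM
- compound 3 `Fc1ccccc1/C=C/c1nnc(-c2ccc3c(c2)OCCO3)o1`: 1160 nM

All three compounds share the same core and were tested in a functional assay on HUVEC cells (Homo sapiens) for antiproliferative activity, read by MTT assay, with a stated time of 48 h; on this read-out lower numbers stand for stronger inhibition and higher numbers for weaker inhibition. Compound 1 stands at the top of the three numbers, which here means the weakest inhibition: the nearest is a 9.1-fold lower number from compound 1 to compound 2 (0.96 log units; beyond the scatter), and the furthest is a 39-fold lower number from compound 1 to compound 3 (1.59 log units; beyond the scatter).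

Compound 4 `Cc1cccc(/C=C/c2nnc(-c3ccc4c(c3)OCCO4)o2)c1` has the same atoms as compound 1, joined differently: 3-methylphenyl in place of 4-methylphenyl on a double-bonded chain carbon bound to a double-bonded chain carbon. For the measured compounds named here, no measured pair shows exactly this move of a methyl group. The closest guide is the move of a fluorine around the same ring, a 4.3-fold lower number from compound 2 to compound 3 (0.63 log units; beyond the scatter), which is modest. The fluoro-for-methyl swap, a 9.1-fold lower number from compound 1 to compound 2 (0.96 log units; beyond the scatter), concerns a different kind of change and bears less directly. Taken together they suggest that where a small group sits on this ring matters, so a modest step toward a lower number in this assay is expected for compound 4, though the direction is far from certain.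

Compound 4 is therefore estimated at 15000 nM in this assay, with a range from 4000 nM to 50000 nM, which corresponds to an expected step of a 3.0-fold lower number from compound 1 to compound 4 (0.48 log units; beyond the scatter).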

Compound 4, half-maximal inhibitory concentration: 40600 nM
Estimate against measurement, compound 4: 2.7-fold (0.43 log units) below; the range from low to high includes it.
By their numbers in this assay, from the lowest: compound 3; then compound 2; then compounds 4 and 1 (each within the scatter of the next).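

In this assay, 3-methylphenyl and 4-methylphenyl cannot be told apart, with a 1.1-fold lower number from compound 1 to compound 4 (0.05 log units; within the scatter), whereas the two fluorophenyl compounds do differ, with a 4.3-fold lower number from compound 2 to compound 3 (0.63 log units; beyond the scatter), so among these four compounds a difference from where the group sits on the ring appears only for fluorine. What separates compound 4 from the others is the kind of group rather than the place alone, with a 35-fold higher number from compound 3 to compound 4 (1.54 log units; beyond the scatter) and an 8.2-fold higher number from compound 2 to compound 4 (0.91 log units; beyond the scatter), and both fluorophenyl compounds therefore stand clearly apart from the methylphenyl pair. Nothing measured here accounts for why the methyl pair reads alike while the fluorine pair does not.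

The compounds shown leave open whether a methyl group placed where compound 3 carries its fluorine would stay with the methylphenyl pair or come closer to compound 3. They also leave open whether a methoxy group or an amine on this ring would read with the methylphenyl pair, with the fluorophenyl pair, or apart from both.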